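Replacing Fluoro with Phenyl in a Cytotoxicity Series

A few compounds are considered here, and "the series" means these few. Any claim that something is new, unique, unknown or untested is made for them only; others in the source may bear on it.

Three compounds share one core and differ only in the group on one aromatic carbon. Compound 1 `CSc1ccc(/C=N/n2c(Cc3ccc(S(C)(=O)=O)cc3)n[nH]c2=S)cc1` carries methylsulfanyl there, compound 2 `CS(=O)(=O)c1ccc(Cc2n[nH]c(=S)n2/N=C/c2ccc(Cl)cc2)cc1` chloro, and compound 3 `CS(=O)(=O)c1ccc(Cc2n[nH]c(=S)n2/N=C/c2ccc(F)cc2)cc1` fluoro. In a functional assay on HeLa cells (Homo sapiens) for cytotoxicity, read by MTT assay, with a stated time of 48 h, tested at 12.5 uM (on this read-out higher numbers stand for a stronger effect at the one concentration tested and lower numbers for a weaker effect), compound 1 gives 27.9%, compound 2 gives 44.7% and compound 3 gives 2.8%, so compound 3 stands lowest of the three, with both others beyond the scatter above it. Between the two larger groups the step is a number 16.8 percentage points higher from compound 1 to compound 2 (beyond the scatter). Compound 4 `CS(=O)(=O)c1ccc(Cc2n[nH]c(=S)n2/N=C/c2ccc(-c3ccccc3)cc2)cc1` is not yet measured; it differs from compound 3 by phenyl in place of fluoro on an aromatic carbon. Among the measured compounds shown here, because a number 41.9 percentage points lower from compound 2 to compound 3 (beyond the scatter) and a number 25.1 percentage points lower from compound 1 to compound 3 (beyond the scatter), each measured step into fluoro went downward, a rise in this assay is expected for compound 4 when fluoro gives way to the larger phenyl, though how far it rises cannot be read from only two steps. Compound 4 is therefore estimated at 40%, within 15% to 65%, which corresponds to an expected step of a number 37.2 percentage points higher from compound 3 to compound 4 (beyond the scatter).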

Compound 4, a percentage reported as activity, at one concentration (the size of the read-out at that concentration, not a potency): 30.4%
Beside the measured number, compound 4's estimate is 9.6 percentage points above it; measured number inside the range.
By their numbers in this assay, from the lowest: compound 3; then compounds 1 and 4 (each within the scatter of the next); then compound 2.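

Phenyl brings a whole aromatic ring onto this aromatic carbon, and in this assay the change from fluoro gives a number 27.6 percentage points higher from compound 3 to compound 4 (beyond the scatter) with a ring in place, so this position accepts a ring without the read-out falling to the level of fluoro. Set against the other two groups, phenyl gives a number 14.3 percentage points lower from compound 2 to compound 4 (beyond the scatter) when it replaces chloro, so the larger group does not reach the top of the series, and a number 2.5 percentage points higher from compound 1 to compound 4 (within the scatter) when it replaces methylsulfanyl, so those two groups cannot be told apart here. Nothing available explains these differences.

On these data alone, whether an amine or a carboxylic acid at this carbon would keep the read-out at this level remains open. As far as these compounds go, it is also open whether a longer chain without a ring would behave like phenyl.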